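The compounds below may be only part of what the source reports. "The series", "measured", "known", "first", "only" and "open" are said of these compounds alone.

Notes on the series. Compound 1 `CNC(=O)c1cc(Oc2ccc3nc(Nc4ccccc4)ncc3c2)ccn1` is the reference. In a physicochemical assay for solubility, at pH 7 (on this read-out higher numbers stand for higher solubility and lower numbers for lower solubility), compound 1 gives < 1000 nM, a limit of the assay rather than a number. Compound 2 `CNC(=O)c1cc(Oc2ccc3nc(Nc4cccc(C(C)(C)C)c4)ncc3c2)ccn1` carries a tert-butyl in place of hydrogen on an aromatic carbon; in this assay compound 2 gives < 1000 nM, again a limit. Compound 3 `CNC(=O)c1cc(Oc2ccc3nc(Nc4ccccc4Oc4ccccc4)ncc3c2)ccn1` bears a phenoxy in place of hydrogen on an aromatic carbon; in this assay compound 3 gives < 1000 nM, also a limit. The steps a step that the two limits leave unreadable from compound 1 to compound 2 and a step that the two limits leave unreadable from compound 1 to compound 3 stay unreadable, all three values sitting at the limit of < 1000 nM in this assay, at which 3 of the 3 values shown sit. Compound 4 `CNC(=O)c1cc(Oc2ccc3nc(Nc4ccc(Oc5ccccc5)cc4)ncc3c2)ccn1` differs from compound 1 by phenoxy in place of hydrogen on an aromatic carbon. Going by the values given here, only the step from compound 1 to compound 3 bears on this change, and it gave no readable size, leaving no sign of a move beyond the scatter. Compound 4 is expected to give 300 nM in this assay, between 50 nM and 1500 nM, most likely once more a limit, a step that the limit leaves unreadable from compound 1 to compound 4.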

Compound 4, solubility: < 1000 nM
Compound 4: only a limit was reported; the forecaster's own chance of this, stated with the estimate: 85%; the middle value lies beyond the limit too.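

Compound 1 and compound 4 both stand at a limit of the assay, so no step between them can be read: the limit of < 1000 nM in this assay, at which 4 of the 4 values shown sit.

The compounds shown leave open whether tert-butyl or phenoxy in place of hydrogen changes the result in this assay at all.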